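Adding a Hydroxy Group to Compound 1

The source may hold more compounds than are shown below. What is called first, only, known or untested is meant among the compounds shown, and "the series" means these compounds.

Measured in a functional assay on HT-29 cells (Homo sapiens) for inhibition, read by sulforhodamine B assay, with a stated time of 72 h; a higher number here means a weaker inhibitor, a lower number a stronger inhibitor:
- compound 1 `COc1ccc(C2C(O)C(=O)N2c2cc(OC)c(OC)c(OC)c2)cc1`: 12 nM
- compound 2 `CCSc1ccc(C2C(Oc3ccccc3)C(=O)N2c2cc(OC)c(OC)c(OC)c2)cc1`: 632 nM
- compound 3 `C=CC1C(=O)N(c2cc(OC)c(OC)c(OC)c2)C1c1ccc(SCC)cc1`: 257 nM

Compound 1 has the lowest number of the three, making it the strongest inhibitor here. Compound 4 `COc1ccc(C2C(O)C(=O)N2c2cc(OC)c(OC)c(OC)c2)cc1O` alters it in one place, with 4-methoxyphenyl becoming 3-hydroxy-4-methoxyphenyl: hydroxy in place of hydrogen on an aromatic carbon. Among the compounds with values here, the only measured step, a 2.5-fold lower number from compound 2 to compound 3 (0.39 log units; beyond the scatter), puts vinyl in place of phenoxy on a saturated ring carbon. That is a modest step, but it is a different change at a different place. Within the data shown here, no measured compound carries this hydroxy, so no step beyond the scatter is expected in this assay. The estimated step is a 1.2-fold lower number from compound 1 to compound 4 (0.08 log units; within the scatter). Compound 4 is expected at 10 nM, with an estimated range from 3 nM to 40 nM.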

Compound 4, half-maximal inhibitory concentration: 463 nM
Beside the measured number, compound 4's estimate is 46-fold (1.67 log units) below it; measured number outside the range, above it.
By their numbers in this assay, from the lowest: compound 1; then compounds 3, 4 and 2 (each within the scatter of the next, the first and the last beyond it).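

Hydroxy in place of hydrogen on this aromatic carbon brings a 39-fold higher number from compound 1 to compound 4 (1.59 log units; beyond the scatter) in this assay, a large step from a change of one heavy atom. Within the data shown here, the only earlier step concerned a saturated ring carbon, so it showed nothing about this ortho-to-methoxy position on the aromatic ring. Nothing measured here accounts for the loss. On these data alone, whether a methoxy group, a fluorine atom or an amine on this same carbon would cost as much remains open.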